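The compounds below may be only part of what the source reports. "The series", "measured", "known", "first", "only" and "open" are said of these compounds alone.

Working notes on the series.

Three analogues sharing one core have been measured in an assay on isolated protein for displacement of a labelled ligand from 5-hydroxytryptamine receptor 6 (Homo sapiens); on this read-out lower numbers stand for stronger inhibition and higher numbers for weaker inhibition. Compound 1 `CN(C)S(=O)(=O)NC[C@@H]1CCCc2cc(S(=O)(=O)c3cccc(F)c3)ccc21` gives 2 nM. Compound 2 `O=S(=O)(c1cccc(F)c1)c1ccc2c(c1)CCC[C@H]2CN1CCCS1(=O)=O` gives 31.6 nM. Compound 3 `O=S(=O)(O)CCCNC[C@@H]1CCCc2cc(S(=O)(=O)c3cccc(F)c3)ccc21` gives 1.26 nM, the lowest of the three numbers; against compound 1 the gap is within the scatter, against compound 2 it is large. The two steps already seen make the pattern plain: a 1.6-fold lower number from compound 1 to compound 3 (0.20 log units; within the scatter), whereas a 25-fold lower number from compound 2 to compound 3 (1.40 log units; beyond the scatter) and a 16-fold higher number from compound 1 to compound 2 (1.20 log units; beyond the scatter). Exchanging the group on the amine nitrogen while keeping the open chain leaves the number where it was; closing that chain into the five-membered ring costs a great deal.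

Compound 4 `CC(=O)N(C)C[C@@H]1CCCc2cc(S(=O)(=O)c3cccc(F)c3)ccc21` is next. acetyl(methyl)amino in place of (3-sulfopropyl)amino on a saturated chain carbon bound to a saturated ring carbon The change keeps an open chain but removes both hydrogen-bond donors and two of three acceptors, so it is not a straight repeat of either measured step. Compound 3 and compound 1 together suggest the amine substituent is tolerant; compound 2 shows that a larger rearrangement in this position can cost much. A moderate step upward in this assay is expected, smaller than a 25-fold lower number from compound 2 to compound 3 (1.40 log units; beyond the scatter) reversed: a 6.3-fold higher number from compound 3 to compound 4 (0.80 log units; beyond the scatter). Compound 4 is thus estimated at 8 nM, with a range from 2 nM to 40 nM.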

Compound 4, inhibition constant: 1.59 nM
Compound 4: the middle estimate sits 5.0-fold (0.70 log units) above what was measured; measured number below the stated range.
By their numbers in this assay, from the lowest: compounds 3, 4 and 1 (each within the scatter of the next); then compound 2.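

In this assay, the open-chain tolerance at this place now extends to acetyl(methyl)amino, a group with no sulfur, no hydrogen-bond donors and 1 hydrogen-bond acceptor: a 1.3-fold higher number from compound 3 to compound 4 (0.10 log units; within the scatter), and a 1.3-fold lower number from compound 1 to compound 4 (0.10 log units; within the scatter), so neither the 3-sulfopropyl chain nor the dimethylsulfamoyl group, nor the hydrogen-bond donors they carry, is needed to hold the number among these compounds. The gap to the ring compound also persists with this much smaller group, a 20-fold lower number from compound 2 to compound 4 (1.30 log units; beyond the scatter), and heavy-atom count does not follow the numbers, since open-chain groups of 5, 7 and 8 heavy atoms sit within the scatter of one another while compound 2, whose ring group has 7, is the one that goes against the open-chain pattern. No measurement on hand accounts for these steps.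

The compounds shown leave open whether the large step belongs to the ring as such or to the sulfonyl within it, a question that a five-membered lactam on the same chain carbon would address. They also leave open how far the tolerance runs, for instance to a plain primary amine or a carboxylic acid on a longer chain.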